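The compounds below may be only part of what the source reports. "The series", "measured", "known", "first", "only" and "open" are said of these compounds alone.

- compound 1 `COC(=O)c1cc(CCCOc2c(C)cc(-c3noc(C(F)(F)F)n3)cc2C)on1`: 35400 nM
- compound 2 `CCOC(=O)c1cc(CCCOc2ccc(-c3noc(C(F)(F)F)n3)cc2)on1`: > 100000 nM (a limit of the assay)
- compound 3 `CCOC(=O)c1cc(CCCOc2ccc(-c3noc(C(F)(F)F)n3)cc2F)on1`: 60200 nM

Within the data shown here, in an ADME assay on HeLa cells (Homo sapiens) for cytotoxicity, read by crystal violet staining, with a stated time of 72 h (a lower number here means that less compound is tolerated, a higher number that more compound is tolerated), only two compounds have actual numbers: compound 1 gives 35400 nM, and compound 3, at 60200 nM, lies within the scatter of it. The entry for compound 2 is a limit.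

Compound 4 `Cc1cc(-c2noc(C(F)(F)F)n2)cc(C)c1OCCCc1cc(C(=O)OC(C)C)no1` has isopropyl in place of methyl on an oxygen next to a carbonyl group. Among the measured compounds shown here, no measured step covers this change. The only one, an at least 1.6-fold lower number from compound 2 to compound 3 (0.22 log units; that floor lies within the scatter), is fluoro in place of hydrogen on an aromatic carbon, so it bears only loosely. No shift beyond the scatter is therefore expected in this assay.

The expected change is a 1.1-fold lower number from compound 1 to compound 4 (0.06 log units; within the scatter). For compound 4 the estimated value is 31000 nM, with an expected range of 13000 nM to 75000 nM.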

Compound 4, half-maximal cytotoxic concentration: 17900 nM
For compound 4 the middle estimate is 1.7-fold (0.24 log units) above the measured one, within the range that was stated.
By their numbers in this assay, from the lowest: compounds 4, 1 and 3 (each within the scatter of the next, the first and the last beyond it). At a limit, above all of these: compound 2.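

In this assay, isopropyl in place of methyl on an oxygen next to a carbonyl group gives a 2.0-fold lower number from compound 1 to compound 4 (0.30 log units; within the scatter). Among these compounds, this is the first reading of methoxycarbonyl to isopropoxycarbonyl, and on the core of compound 1 the step stays within the scatter. Nothing at hand gives a cause for this step.

As far as these compounds go, whether a carboxylic acid or an amide at this place would stay within the scatter of compound 1 remains open. So does the effect of a longer chain on that oxygen.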